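A fluoro added to compound 1

A few compounds are considered here, and "the series" means these few. Any claim that something is new, unique, unknown or untested is made for them only; others in the source may bear on it.

Measured in a functional assay on PBMC cells (Homo sapiens) for inhibition, read by HTRF, with stated times of 15 min and 24 h; on this read-out higher numbers stand for weaker inhibition and lower numbers for stronger inhibition
Compound 1 `O=C(Nc1ccc2c(c1)B(O)OC2)c1ccccc1C(F)(F)F` gives 4400 nM
Compound 2 `O=C(Nc1ccc2c(c1)B(O)OC2)c1ccccc1OC(F)(F)F` gives > 100000 nM as a limit

Going by the values given here, compound 1 holds the only true number in this assay (4400 nM). Compound 2 stands at a limit of the assay (> 100000 nM). Compound 3 (`O=C(Nc1ccc2c(c1)B(O)OC2)c1cc(F)ccc1C(F)(F)F`) keeps the core of compound 1 and carries one change (fluoro in place of hydrogen on an aromatic carbon): fluoro in place of hydrogen on an aromatic carbon, para to a trifluoromethyl group. Among the compounds with values here, only one measured step lies near this change, and it is large (an at least 22-fold higher number from compound 1 to compound 2 (1.35 log units; beyond the scatter)). That step replaces the trifluoromethyl group, which compound 3 keeps, so it sets no size for the new fluoro. A small step of uncertain direction is therefore expected, possibly none beyond the scatter (a 1.3-fold lower number from compound 1 to compound 3 (0.10 log units; within the scatter)). Compound 3 is estimated at 3500 nM (expected range 900 nM to 15000 nM).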

Compound 3, half-maximal inhibitory concentration: 8200 nM
Estimate against measurement, compound 3: 2.3-fold (0.37 log units) below; the range from low to high includes it.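

In this assay the added fluoro, para to a trifluoromethyl group, brings a 1.9-fold higher number from compound 1 to compound 3 (0.27 log units; within the scatter). The earlier compounds shown here spoke only of replacing the trifluoromethyl group itself, and that change ended at a limit of the assay. Compound 3 adds a second true number and shows that, with the trifluoromethyl group kept, this aromatic carbon takes a fluoro without a change beyond the scatter, though nothing at hand gives a reason for the size of this step. From the compounds shown here alone, whether a chloro, a methoxy group, a nitrile or an amine at this same carbon would stay as close to compound 1 remains open. So does whether a fluoro on the other free carbons of this ring would behave in the same way.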